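The source may report more compounds than this note shows. Statements on the series, on what has been measured and on what is new or still open speak of the compounds shown alone.

Compound 1 `COc1cc2ncnc(-n3nc(-c4ccccn4)nc3N)c2cc1[N+](=O)[O-]`: 2000 nM
Compound 2 `COc1cc2ncnc(-n3nc(-c4ccccn4)cc3N)c2cc1OC`: 1000 nM

Both numbers come from a physicochemical assay for solubility, in phosphate buffer, with a stated time of 18 h, at pH 7.4; on this read-out higher numbers stand for higher solubility and lower numbers for lower solubility. On these numbers, compound 1 at 2000 nM cannot be told apart from compound 2 at 1000 nM. The two lie within the usual scatter of repeated measurements, so neither stands clearly apart.

Compound 3 `COc1cc2ncnc(-n3nc(-c4ccccn4)nc3N)c2cc1OCCCNC(=O)OC(C)(C)C` has not yet been measured in this assay. It keeps the core of compound 1, but 3-((tert-butoxycarbonyl)amino)propoxy stands in place of nitro on an aromatic carbon, ortho to a methoxy group: 3-((tert-butoxycarbonyl)amino)propoxy in place of nitro on an aromatic carbon.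

For the measured compounds named here, no measured pair shows this swap on its own, and neither measured compound carries the new chain, so the data offer only a rough guide. A modest drop is expected, perhaps none beyond the scatter, and the estimate is a 2.0-fold lower number from compound 1 to compound 3 (0.30 log units; within the scatter). This expectation leans on the narrow spread of the two measured numbers, with compound 2 at 1000 nM as the closest reference. For compound 3 the expected value is 1000 nM, with an estimated range from 300 nM to 4000 nM.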

Compound 3, solubility: 2000 nM
Estimate against measurement, compound 3: 2.0-fold (0.30 log units) below; low and high end bracket the measured number.
By their numbers in this assay, from the lowest: compounds 2, 1 and 3 (each within the scatter of the next).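

In this assay, putting 3-((tert-butoxycarbonyl)amino)propoxy in place of nitro on an aromatic carbon, ortho to a methoxy group, gives no change at the digits printed from compound 1 to compound 3 (within the scatter). For the compounds shown here, this is the first step here that changes one place alone, and it shows that on the core of compound 1 this position can take a chain of 12 heavy atoms, carrying 1 hydrogen-bond donor, in place of a group of 3 heavy atoms without a readable shift in this read-out. Nothing measured here offers a reason for this outcome.

From the compounds shown here alone, the result rests on one swap, so it remains open whether the tert-butoxycarbonyl cap on the chain plays any part: a free primary amine at the end of the propoxy chain, a carboxylic acid there, or a longer chain could each read differently in this assay. Going by these compounds, it also remains open whether a small group at this position, such as a hydroxyl or a fluorine, would fit the same flat picture, since a single step cannot establish a trend for the position.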